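A Trifluoromethoxyphenyl Variant Built From Compound 3

This account rests on a few compounds, and the source may have more. Where it says the series, first, only, none or still open, it means among the compounds named here.

Compound 1 `COc1ccc(C(=O)c2cc(OC)c(OC)c(OC)c2)cc1N`: 2100 nM
Compound 2 `COc1ccc(C(=O)c2cc(OC)c(OC)c(OC)c2)cc1NC(=O)/C=C/c1cc(OC)c(OC)c(OC)c1`: 6300 nM
Compound 3 `COc1ccc(C(=O)c2cc(OC)c(OC)c(OC)c2)cc1NC(=O)/C=C/c1ccc(F)cc1`: 3900 nM

In a functional assay on DU-145 cells (Homo sapiens) for cytotoxicity, read by MTT assay, with a stated time of 72 h (a lower number here means a stronger inhibitor, a higher number a weaker inhibitor), compound 3 stands second highest of the three numbers; its nearest neighbour is compound 2, with a 1.6-fold lower number from compound 2 to compound 3 (0.21 log units; within the scatter), and its furthest is compound 1, with a 1.9-fold higher number from compound 1 to compound 3 (0.27 log units; within the scatter). Compound 4 `COc1ccc(C(=O)c2cc(OC)c(OC)c(OC)c2)cc1NC(=O)/C=C/c1cccc(OC(F)(F)F)c1` differs from compound 3 by 3-(trifluoromethoxy)phenyl in place of 4-fluorophenyl on a double-bonded chain carbon bound to a double-bonded chain carbon. Both measured steps bear on it: the step from compound 2 to compound 3 is a swap at the same place, and the step from compound 1 to compound 3 adds the whole chain, yet neither moved beyond the scatter. He therefore expects no step beyond the scatter in this assay for compound 4, an estimated 1.0-fold higher number from compound 3 to compound 4 (0.01 log units; within the scatter), giving compound 4 an expected 4000 nM within 1500 nM to 11000 nM.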

Compound 4, half-maximal inhibitory concentration: 10200 nM
For compound 4 the middle estimate is 2.6-fold (0.41 log units) below the measured one; the range from low to high includes it.
By their numbers in this assay, from the lowest: compounds 1, 3, 2 and 4 (each within the scatter of the next, the first and the last beyond it).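

At this place on the chain, this assay now shows a swap of the ring group that moves the number beyond the scatter: a 2.6-fold higher number from compound 3 to compound 4 (0.42 log units; beyond the scatter) is modest, but neither earlier step went that far. Set against the 3,4,5-trimethoxyphenyl group, the same entering group stays within the scatter, with a 1.6-fold higher number from compound 2 to compound 4 (0.21 log units; within the scatter) as the step. Nothing measured here explains the step from the 4-fluorophenyl group.

The compounds shown leave open how a phenyl ring carrying an amine or a carboxylic acid would read at this place. They also leave open whether a plain unsubstituted phenyl would stand closer to compound 3 or to compound 4.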